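The compounds below may be only part of what the source reports. "The series", "measured", "known", "first", "only" and "open" are said of these compounds alone.

Measured so far:
Compound 1 `Cc1cc(/C=C2\SC(=S)N(Cc3ccccc3)C2=O)c(C)n1-c1ccc(O)c(C(=O)O)c1`: 159000 nM
Compound 2 `Cc1cc(/C=C2\SC(=S)N(Cc3cccc(C(F)(F)F)c3)C2=O)c(C)n1-c1ccc(O)c(C(=O)O)c1`: 26300 nM

In an ADME assay on MT2 cells (Homo sapiens) for cytotoxicity, read by XTT assay, with a stated time of 4 days (on this read-out lower numbers stand for higher toxicity in this test and higher numbers for lower toxicity in this test), compound 1 stands highest of the two numbers measured; its nearest neighbour is compound 2, reached by trifluoromethyl in place of hydrogen on an aromatic carbon, a step of a 6.0-fold lower number from compound 1 to compound 2 (0.78 log units; beyond the scatter). Compound 3 `Cc1cc(/C=C2\SC(=S)N(Cc3cccc(Br)c3)C2=O)c(C)n1-c1ccc(O)c(C(=O)O)c1` differs from compound 1 by bromo in place of hydrogen on an aromatic carbon, that is, benzyl to 3-bromobenzyl. For the measured compounds named here, only that one measured step bears on the change, so a lower number is expected for compound 3 in this assay, though likely a smaller drop. Compound 3 is estimated at 50000 nM, with a range from 20000 nM to 130000 nM. That estimate means a step of a 3.2-fold lower number from compound 1 to compound 3 (0.50 log units; beyond the scatter).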

Compound 3, half-maximal cytotoxic concentration: 48200 nM
Estimate against measurement, compound 3: 1.0-fold (0.02 log units) above; the range from low to high includes it.
By their numbers in this assay, from the lowest: compounds 2 and 3 (each within the scatter of the next); then compound 1.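

In this assay, a second group at this place on the benzyl ring also lowers the number, with bromo giving a 3.3-fold lower number from compound 1 to compound 3 (0.52 log units; beyond the scatter), so the trifluoromethyl result does not stand alone. Exchanging one group for the other gives a 1.8-fold higher number from compound 2 to compound 3 (0.26 log units; within the scatter), which leaves bromo and trifluoromethyl indistinguishable in this test. Nothing measured here accounts for the drop.

From the compounds shown here alone, whether a methoxy group, an amine or a carboxylic acid at this place would also lower the number remains open. So does the effect of bromo at other places on this ring.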